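The source may report more compounds than this note shows. Statements on the series, on what has been measured and on what is new or still open speak of the compounds shown alone.

In a functional assay on the whole organism for inhibition, with Mus musculus as the target (on this read-out higher numbers stand for an effect only at larger amounts of compound and lower numbers for an effect already at smaller amounts), compound 1 `CN1Cc2c(N)cccc2C(c2ccc(F)cc2)C1` gives 0.25 mg/kg and compound 2 `CCOC(=O)Nc1cccc2c1CN(C)CC2c1ccccc1` gives about 4 mg/kg. Compound 3 `CCOC(=O)Nc1cccc2c1CN(C)CC2c1ccc(Cl)cc1` gives 0.6 mg/kg, the second highest of the three numbers. Compound 4 `CCOC(=O)Nc1cccc2c1CN(C)CC2c1ccc(F)cc1` has not yet been measured and differs from compound 3 by a single change: fluoro in place of chloro on an aromatic carbon. This is fluoro in place of chloro on an aromatic carbon, para to a large group.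

Among the measured compounds shown here, the one measured step at this place is a 6.7-fold lower number from compound 2 to compound 3 (0.82 log units; beyond the scatter), with chloro in place of hydrogen, a modest change beyond the scatter. For the measured compounds named here, it does not show what fluoro does there, and no measured pair exchanges chloro for fluoro. Compound 1 also carries the 4-fluorophenyl group and reaches 0.25 mg/kg, but it differs from compound 3 elsewhere as well, so it offers only loose support.

In this assay, only a small rise, not beyond the scatter, is therefore expected. The estimated step is a 1.3-fold higher number from compound 3 to compound 4 (0.12 log units; within the scatter). For compound 4 the estimated value is 0.8 mg/kg, with an expected range from 0.3 mg/kg to 2 mg/kg.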

Compound 4, dose for half-maximal effect: 3.3 mg/kg
The estimate for compound 4 lay 4.1-fold (0.62 log units) below the measured number, and the stated range ends below it.
By their numbers in this assay, from the lowest: compound 1; then compound 3; then compounds 4 and 2 (each within the scatter of the next).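

In this assay, among the compounds shown here, the two halogens do not act alike at this place: a 5.5-fold higher number from compound 3 to compound 4 (0.74 log units; beyond the scatter), whereas fluoro in place of hydrogen gives a 1.2-fold lower number from compound 2 to compound 4 (0.08 log units; within the scatter), so of these three compounds only the one with chloro stands apart. With the 4-fluorophenyl group held constant, the ethoxycarbonyl on the nitrogen on the aromatic ring also makes a difference, with a 13-fold higher number from compound 1 to compound 4 (1.12 log units; beyond the scatter), so the low number of compound 1 does not carry over to the compound with this group. Nothing at hand explains either difference.

As far as these compounds go, it remains open whether the lower number is specific to chloro or is shared by bromo, methyl or methoxy at this place. From the compounds shown here alone, it is equally open how chloro would behave with hydrogen on that nitrogen, or with an acetyl group there in place of ethoxycarbonyl.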